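From 4-cyanophenyl to 2-nitrophenyl on the shared core

The compounds below may be only part of what the source reports. "The series", "measured", "known", "first", "only" and "open" are said of these compounds alone.

Measured so far in a functional assay with Homo sapiens as the target; on this read-out lower numbers stand for stronger inhibition and higher numbers for weaker inhibition:
Compound 1 `CC(C)[C@H](NC(=O)COc1cccc2ccccc12)C(=O)N[C@@H](CC(=O)O)C(=O)COc1ccc(C(F)(F)F)cc1` gives 12300 nM
Compound 2 `CC(C)[C@H](NC(=O)COc1cccc2ccccc12)C(=O)N[C@@H](CC(=O)O)C(=O)COc1ccc(C#N)cc1` gives 26700 nM

Compound 2 at 26700 nM has the higher of the two numbers and is thus the weaker inhibitor of the pair. Compound 3 `CC(C)[C@H](NC(=O)COc1cccc2ccccc12)C(=O)N[C@@H](CC(=O)O)C(=O)COc1ccccc1[N+](=O)[O-]` differs from compound 2 in one place (2-nitrophenyl in place of 4-cyanophenyl on an oxygen on a saturated carbon) with 2-nitrophenyl in place of 4-cyanophenyl on an oxygen on a saturated carbon. Among the compounds with values here, only one measured step offers any guide. That step, a 2.2-fold higher number from compound 1 to compound 2 (0.34 log units; beyond the scatter) when cyano replaced trifluoromethyl on an aromatic carbon, was modest. Within the data shown here, no compound carrying a nitro group has been measured, so the step bears only loosely on this change and gives no direction. The estimated move is a 1.3-fold lower number from compound 2 to compound 3 (0.13 log units; within the scatter) and no change beyond the scatter is expected in this assay for now. Expected for compound 3 is 20000 nM within a range of 7000 nM to 55000 nM in this estimate.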

Compound 3, half-maximal inhibitory concentration: 27700 nM
The estimate for compound 3 lay 1.4-fold (0.14 log units) below the measured number; the range from low to high includes it.
By their numbers in this assay, from the lowest: compound 1; then compounds 2 and 3 (each within the scatter of the next).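

In this assay, replacing 4-cyanophenyl with 2-nitrophenyl on this oxygen gave a 1.0-fold higher number from compound 2 to compound 3 (0.02 log units; within the scatter), so compound 2 and compound 3 cannot be told apart, although the two groups differ in both substituent and substitution pattern. The comparison with the trifluoromethyl compound gave a 2.3-fold higher number from compound 1 to compound 3 (0.35 log units; beyond the scatter), leaving compound 1 with the lowest number of the three by a modest margin, with the nitrile and nitro compounds level with each other. No independent measurement bears on this result.

Since the last step alters the substituent and its ring position together, the compounds shown cannot separate the contribution of each. They also leave open how an unsubstituted phenyl, or a ring carrying an amine or a carboxylic acid, would read out at this position.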